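The compounds below may be only part of what the source reports. "The series", "measured", "known", "first", "only" and "open" are said of these compounds alone.

The compounds here share one core and differ only in the group on a single aromatic carbon. Compound 1 `CCCC#Cc1cc([C@@H]2O[C@H](CO)[C@@H](O)[C@H]2O)n2ncnc(N)c12` carries a pent-1-yn-1-yl group there, and in a functional assay on HL-60 cells (Homo sapiens) for antiproliferative activity, with a stated time of 72 h (a lower number here means a stronger inhibitor, a higher number a weaker inhibitor), compound 1 gives 200 nM. That is the only number shown; the other value is a limit. Compound 2 `Nc1ncnn2c([C@@H]3O[C@H](CO)[C@@H](O)[C@H]3O)cc(-c3ccccc3F)c12` carries a 2-fluorophenyl group instead, and in this assay compound 2 reaches only the limit of > 100000 nM. Thus an at least 500-fold higher number from compound 1 to compound 2 (2.69 log units; beyond the scatter). Compound 3 `Nc1ncnn2c([C@@H]3O[C@H](CO)[C@@H](O)[C@H]3O)cc(/C=C/c3ccccc3)c12` has not yet been measured: 2-phenylethenyl in place of pent-1-yn-1-yl on an aromatic carbon. The entering 2-phenylethenyl group brings a six-membered aromatic ring, as compound 2 does, yet keeps a chain with a double bond outside the ring, which compound 2 lacks. Going by the values given here, only the step to compound 2 bears on this change, and it was large, so a clear loss is expected, though a smaller one. The expected step is a 15-fold higher number from compound 1 to compound 3 (1.18 log units; beyond the scatter). Compound 3 is therefore estimated at 3000 nM, between 300 nM and 50000 nM.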

Compound 3, half-maximal inhibitory concentration: 2000 nM
Beside the measured number, compound 3's estimate is 1.5-fold (0.18 log units) above it; the range from low to high includes it.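

Replacing the ring directly on the core with 2-phenylethenyl gives an at least 50-fold lower number from compound 2 to compound 3 (1.69 log units; beyond the scatter), so in this assay a six-membered aromatic ring at this position can coexist with activity when a double bond outside the ring carries it. Compound 2 sits at a limit rather than a number, so that step gives only a bound on the gain: the limit of > 100000 nM in this assay, at which 1 of the 3 values shown sits. Even so, the ring-bearing group does not match the open chain, as 2-phenylethenyl in place of pent-1-yn-1-yl gives a 10-fold higher number from compound 1 to compound 3 (1.00 log units; beyond the scatter).

This change swaps the triple bond for a double bond and adds the ring in one move, so which of these accounts for the modest loss stays open. A phenylethynyl group, which places the same ring on a triple bond, would separate the two.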